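Chloro in place of hydrogen on the benzyl ring

The source may hold more compounds than are shown below. What is called first, only, known or untested is meant among the compounds shown, and "the series" means these compounds.

Compound 1, `Cc1ccc(NC(=S)NC(=O)Nc2ccc3c(c2)C(=O)C(=O)N3Cc2ccccc2)cc1`, stands highest in a physicochemical assay for lipophilicity, in phosphate buffer, measured as octanol-water partition (a higher number here means a more lipophilic compound, a lower number a more polar compound), among the three measured compounds with 2.96. Compound 2, `COc1ccccc1NC(=S)NC(=O)Nc1ccc2c(c1)C(=O)C(=O)N2Cc1ccccc1`, gives 2.38, and compound 3, `COc1ccc(NC(=S)NC(=O)Nc2ccc3c(c2)C(=O)C(=O)N3Cc2ccccc2)cc1`, gives 2.39. The two steps away from compound 1 were a number 0.58 log units lower from compound 1 to compound 2 (beyond the scatter) and a number 0.57 log units lower from compound 1 to compound 3 (beyond the scatter), while between the two methoxy compounds the step was a number 0.01 log units higher from compound 2 to compound 3 (within the scatter).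

The new compound 4, `Cc1ccc(NC(=S)NC(=O)Nc2ccc3c(c2)C(=O)C(=O)N3Cc2ccccc2Cl)cc1`, differs from compound 1 in one place: chloro in place of hydrogen on an aromatic carbon. The entering group brings one heavy atom, a chlorine, with no ring, no hydrogen-bond donors and no hydrogen-bond acceptors, and sits on the benzyl ring of the shared core, ortho to a large group.

Among the measured compounds shown here, none of the measured steps touches this ring; all three concern the exchange of methyl and methoxy on the other aryl group, and both steps from compound 1 moved the partition coefficient lower by a modest amount. For compound 4 a change in the opposite direction is therefore expected, estimated as a number 0.64 log units higher from compound 1 to compound 4 (beyond the scatter). Compound 4 is expected to reach about 3.6 in this assay, with a range from 3.2 to 4.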

Compound 4, partition coefficient: 3.73
Beside the measured number, compound 4's estimate is 0.13 log units below it; measured number inside the range.
By their numbers in this assay, from the lowest: compounds 2 and 3 (each within the scatter of the next); then compound 1; then compound 4.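

Among the compounds shown here, the benzyl ring of the shared core, which none of the earlier steps touched, proves to be a place where one small substitution shifts the read-out in this assay: chloro in place of hydrogen, on an aromatic carbon ortho to a large group, gives a number 0.77 log units higher from compound 1 to compound 4 (beyond the scatter). All the earlier changes lay on the other aryl group, and both steps leading away from compound 1 went lower, so this is the first step shown that goes upward from compound 1. The number in this assay can therefore be moved in either direction from compound 1, by changes in two different places, although no measurement shown bears on what lies behind this particular step.

Going by these compounds, it remains open whether the same chloro would produce a similar step on the methoxy compounds, compound 2 and compound 3, whose benzyl ring carries no substituent. Also open, on these data alone, is whether the step is particular to chloro, or whether a fluoro, an amine or a carboxylic acid on this ring would move the number in the same direction, or in the opposite one.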